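Swapping the halophenyl for a methoxyphenyl in an aldehyde dehydrogenase series

A few compounds are considered here, and "the series" means these few. Any claim that something is new, unique, unknown or untested is made for them only; others in the source may bear on it.

In an assay on isolated protein for inhibition of aldehyde dehydrogenase 1A1 (Homo sapiens), read by spectrophotometry, tested at 10 uM (a lower number here means less inhibition, a higher number more inhibition at the concentration tested (going by the name of the read-out)), compound 1 `O=C(C1CC1)N1CCN(Cc2nc3ccccc3n2Cc2ccccc2F)CC1` gives 40.7%. Going by the values given here, compound 2 `O=C(C1CC1)N1CCN(Cc2nc3ccccc3n2Cc2ccc(Cl)cc2)CC1` stands highest of the two numbers so far, giving 56.6% in this assay, and the only measured step, a number 15.9 percentage points higher from compound 1 to compound 2 (beyond the scatter), shows that the aryl group on the saturated chain carbon bound to the aromatic nitrogen does move the read-out. Compound 3 `COc1cccc(Cn2c(CN3CCN(C(=O)C4CC4)CC3)nc3ccccc32)c1` differs from compound 2 in exactly that position: 3-methoxyphenyl in place of 4-chlorophenyl on a saturated chain carbon bound to an aromatic nitrogen. That step bears on the present change only in place, not in kind, since no methoxyphenyl has been measured here. A step of modest size in either direction, or none beyond the scatter, is therefore possible; the account expects a small loss, a number 11.6 percentage points lower from compound 2 to compound 3 (beyond the scatter). Compound 3 is estimated to give 45% in this assay, within a range of 25% to 65%.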

Compound 3, a percentage reported as inhibition, at one concentration (the size of the read-out at that concentration, not a potency): 44.4%
Compound 3: middle estimate off by 0.6 percentage points, on the high side; the range from low to high includes it.
By their numbers in this assay, from the lowest: compounds 1 and 3 (each within the scatter of the next); then compound 2.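

Replacing the 4-chlorophenyl with the 3-methoxyphenyl on a saturated chain carbon bound to an aromatic nitrogen gives a number 12.2 percentage points lower from compound 2 to compound 3 (beyond the scatter) in this assay, so this methoxy-bearing group does not keep the higher reading of compound 2. Replacing the 2-fluorophenyl with the same group gives a number 3.7 percentage points higher from compound 1 to compound 3 (within the scatter), which leaves the 4-chlorophenyl as the only one of the three aryl groups whose reading stands apart from the others. Nothing available explains why these groups differ at this position.

Going by these compounds, the three aryl groups differ in both the substituent and where it sits, so it remains open whether the higher reading of compound 2 goes with the chlorine or with its place on the ring. An unsubstituted phenyl, a 3-chlorophenyl or a 4-methoxyphenyl at this position would help to separate the two.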